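From compound 3 to compound 4: a phenyl swap

The source may hold more compounds than are shown below. What is called first, only, known or untested is meant among the compounds shown, and "the series" means these compounds.

compound 1 `COc1ccc(C2=C(c3cc(OC)c(OC)c(OC)c3)C(=O)CC2O[SiH2]C(C)(C)C)cc1`: > 100 ug/mL
compound 2 `COC(=O)c1cc(C2=C(c3cc(OC)c(OC)c(OC)c3)C(=O)CC2O[SiH2]C(C)(C)C)ccc1OC`: > 100 ug/mL
compound 3 `COc1ccc(C2=C(c3cc(OC)c(OC)c(OC)c3)C(=O)CC2O[SiH2]C(C)(C)C)cc1OC`: > 100 ug/mL

All three entries in an ADME assay on HEK293 cells (Homo sapiens) for cytotoxicity, read by MTT assay, with a stated time of 72 h (a lower number here means a stronger inhibitor, a higher number a weaker inhibitor), are limits of the assay, not numbers. Compound 3 gives > 100 ug/mL, which is a limit. Its standing within the series cannot be ranked, and the only summary available is the limit of > 100 ug/mL in this assay, at which 3 of the 3 values shown sit.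

Compound 4 `COc1cc(C2=C(c3ccccc3)C(O[SiH2]C(C)(C)C)CC2=O)cc(OC)c1OC` carries phenyl in place of 3,4-dimethoxyphenyl on a double-bonded ring carbon.

The closest measured change is a step that the two limits leave unreadable from compound 1 to compound 3, with methoxy in place of hydrogen on an aromatic carbon. The other two comparisons are a step that the two limits leave unreadable from compound 1 to compound 2 and a step that the two limits leave unreadable from compound 2 to compound 3. Among the compounds with values here, none of these gives a size that can be carried over to the new change, and no measured compound yet has a number in this assay.

No step beyond the scatter is therefore expected in this assay, and a further limit is the likeliest report. The expected step is a step that the limit leaves unreadable from compound 3 to compound 4. For compound 4 the estimated value is 150 ug/mL, with an expected range of 70 ug/mL to 400 ug/mL.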

Compound 4, half-maximal inhibitory concentration: > 100 ug/mL
Compound 4: only a limit was reported; the forecaster's own chance of this, stated with the estimate: 85%; the middle value is on the limit's open side.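

In this assay compound 4 gives > 100 ug/mL, which is a limit and not a number, so its steps from compound 1, compound 2 and compound 3 cannot be read. The series has one summary: the limit of > 100 ug/mL in this assay, at which 4 of the 4 values shown sit.

The compounds shown leave open whether any change to the shared core gives a readable value in this assay.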